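The compounds below may be only part of what the source reports. "The series", "measured", "known", "first", "only" and "open" are said of these compounds alone.

Working notes on the series. In a functional assay on K562 cells (Homo sapiens) for cytotoxicity, read by MTT assay, with a stated time of 48 h (on this read-out lower numbers stand for stronger inhibition and higher numbers for weaker inhibition), compound 1 `Cc1ccc(CN2CCN(C(=O)CN[C@H]3CCN(S(=O)(=O)Cc4ccccc4)C3)CC2)cc1` gives 8200 nM and compound 2 `O=C(CN[C@H]1CCN(S(=O)(=O)Cc2ccccc2)C1)N1CCN(Cc2ccccc2Cl)CC1` gives 9000 nM while compound 3 `O=C(CN[C@H]1CCN(S(=O)(=O)Cc2ccccc2)C1)N1CCN(Cc2ccccc2F)CC1` gives 12600 nM with no separation among the three. Compound 3 stands level with the other two, since the steps to it are a 1.5-fold higher number from compound 1 to compound 3 (0.19 log units; within the scatter) and a 1.4-fold higher number from compound 2 to compound 3 (0.15 log units; within the scatter) and neither leaves the scatter.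

The next compound is compound 4 `O=C(CN[C@H]1CCN(S(=O)(=O)Cc2ccccc2)C1)N1CCN(Cc2cccc(C(F)(F)F)c2)CC1` with this difference from compound 3: 3-(trifluoromethyl)phenyl in place of 2-fluorophenyl on a saturated chain carbon bound to an amine nitrogen in a ring. In words, this is 3-(trifluoromethyl)phenyl in place of 2-fluorophenyl on a saturated chain carbon bound to an amine nitrogen in a ring.

For the measured compounds named here, no measured compound carries trifluoromethyl, so the evidence is indirect. Going by the values given here, the steps that bear on the change are those at the same place, namely a 1.1-fold higher number from compound 1 to compound 2 (0.04 log units; within the scatter) together with the two steps above. All three are small, and the data hold no step beyond the scatter for any exchange of this group.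

In this assay the expected step is a 1.3-fold lower number from compound 3 to compound 4 (0.10 log units; within the scatter) and no size or direction beyond the scatter is expected. The estimate for compound 4 is 10000 nM with an expected range from 5000 nM to 20000 nM as its span.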

Compound 4, half-maximal inhibitory concentration: 3600 nM
For compound 4 the middle estimate is 2.8-fold (0.44 log units) above the measured one; measured number below the stated range.
By their numbers in this assay, from the lowest: compound 4; then compounds 1, 2 and 3 (each within the scatter of the next).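

In this assay the place on a saturated chain carbon bound to an amine nitrogen in a ring shows its first steps beyond the scatter, with a 3.5-fold lower number from compound 3 to compound 4 (0.54 log units; beyond the scatter) and a 2.5-fold lower number from compound 2 to compound 4 (0.40 log units; beyond the scatter) and a 2.3-fold lower number from compound 1 to compound 4 (0.36 log units; beyond the scatter) all modest, whereas exchanges among 2-fluorophenyl, 2-chlorophenyl and 4-methylphenyl stayed within it. This position therefore does respond to the group it carries, and 3-(trifluoromethyl)phenyl, with 10 heavy atoms against 7 for 2-fluorophenyl, sets compound 4 apart as the lowest number of the four, the three earlier compounds remaining level with one another. No measurement at hand accounts for this separation.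

The compounds shown leave open whether the step belongs to the trifluoromethyl group itself or to its location on the phenyl ring, since the change from compound 3 to compound 4 alters both at once. A 2-(trifluoromethyl)phenyl or a 3-fluorophenyl group would separate these two readings, and a 3-methoxyphenyl or 3-cyanophenyl group would show whether the gain extends beyond trifluoromethyl.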